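The source may report more compounds than this note shows. Statements on the series, on what has been measured and on what is new or still open speak of the compounds shown alone.

Going by the values given here, in a functional assay on HT-29 cells (Homo sapiens) for cytotoxicity, read by MTT assay, with a stated time of 72 h (on this read-out higher numbers stand for weaker inhibition and lower numbers for stronger inhibition), compound 1 `COc1cc2c(Oc3ccc(NC(=O)/C=C/S(=O)(=O)c4ccccc4OC)cc3F)ccnc2cc1OCCCN1CCN(C)CC1` gives 270 nM, and compound 2 `COc1ccc(S(=O)(=O)/C=C/C(=O)Nc2ccc(Oc3ccnc4cc(OCCCN5CCN(C)CC5)c(OC)cc34)c(F)c2)cc1` gives 1660 nM, the higher of the two numbers, with compound 1 as its only neighbour. Among the compounds with values here, the single measured step, a 6.1-fold higher number from compound 1 to compound 2 (0.79 log units; beyond the scatter), alters where a methoxy sits rather than what it is. Compound 3 `COc1cc2c(Oc3ccc(NC(=O)/C=C/S(=O)(=O)c4ccc(C)cc4)cc3F)ccnc2cc1OCCCN1CCN(C)CC1` differs from compound 2 by methyl in place of methoxy on an aromatic carbon. Within the data shown here, no measured step swaps methyl for methoxy, so the data give no direct guide; the step of a 1.3-fold lower number from compound 2 to compound 3 (0.11 log units; within the scatter) is expected to stay within the scatter. Compound 3 is therefore estimated at 1300 nM, within 450 nM to 3800 nM.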

Compound 3, half-maximal inhibitory concentration: 2070 nM
Compound 3: middle estimate off by 1.6-fold (0.20 log units), on the low side; low and high end bracket the measured number.
By their numbers in this assay, from the lowest: compound 1; then compounds 2 and 3 (each within the scatter of the next).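

In this assay, putting methyl in place of methoxy, para to a large group, leaves the number within the scatter, with a 1.2-fold higher number from compound 2 to compound 3 (0.10 log units; within the scatter) as the step. At this place, then, 4-methylphenyl and 4-methoxyphenyl cannot be told apart, and the 2-methoxyphenyl of compound 1 stays clear of both, with a 7.7-fold higher number from compound 1 to compound 3 (0.88 log units; beyond the scatter) as the second step. Nothing available explains either step. On these data alone, whether an amine, a chlorine or a longer chain such as ethoxy in that same place would stay level with compound 2 and compound 3 remains open.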